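A few compounds are considered here, and "the series" means these few. Any claim that something is new, unique, unknown or untested is made for them only; others in the source may bear on it.

Three compounds have been measured in an assay on isolated protein for displacement of a labelled ligand from 5-hydroxytryptamine receptor 6 (Homo sapiens); on this read-out higher numbers stand for weaker inhibition and lower numbers for stronger inhibition:

compound 1 `NC[C@@H]1CCCc2cc(S(=O)(=O)c3cc[nH]c3)ccc21` gives 0.316 nM
compound 2 `NC[C@@H]1CCCc2cc(S(=O)(=O)c3cc(F)cc4[nH]cnc34)ccc21` gives 5.01 nM
compound 3 `CNS(=O)(=O)NC[C@@H]1CCCc2cc(S(=O)(=O)c3cccc(F)c3)ccc21` gives 1 nM

Compound 3 stands second highest of the three numbers. Compound 1 sits below it and compound 2 above it, and both of those gaps lie beyond the usual scatter of this assay, so compound 3 is weaker than compound 1 and stronger than compound 2 on this read-out. The three compounds share a core but differ in two places at once, the group on the sulfone and the group on the saturated chain carbon, so none of the pairs gives a clean single step.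

Compound 4 `CN(CC(N)=O)C[C@@H]1CCCc2cc(S(=O)(=O)c3cccc(F)c3)ccc21` has not yet been measured. It differs from compound 3 in one place: (carbamoylmethyl)(methyl)amino in place of (methylsulfamoyl)amino on a saturated chain carbon bound to a saturated ring carbon. The sulfone side is unchanged from compound 3.

Going by the values given here, no measured pair shows this exact change, so the expectation rests only on compound 3 and its value of 1 nM in this assay. Compound 4 is expected to land close to compound 3, with a step from compound 3 to compound 4 of a 1.5-fold higher number from compound 3 to compound 4 (0.18 log units; within the scatter), which is not beyond the scatter. Compound 4 is therefore estimated at 1.5 nM, within a range from 0.3 nM to 8 nM.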

Compound 4, inhibition constant: 1.26 nM
For compound 4 the middle estimate is 1.2-fold (0.08 log units) above the measured one; the range from low to high includes it.
By their numbers in this assay, from the lowest: compound 1; then compounds 3 and 4 (each within the scatter of the next); then compound 2.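

At the saturated chain carbon bound to a saturated ring carbon, a whole group can be exchanged with little visible effect in this assay: the step is a 1.3-fold higher number from compound 3 to compound 4 (0.10 log units; within the scatter) and does not separate the two compounds. The change removes (methylsulfamoyl)amino, with its sulfur and 2 hydrogen-bond donors, and puts in (carbamoylmethyl)(methyl)amino, with no sulfur and 1 hydrogen-bond donor, so for this pair neither the sulfur nor the second donor is needed to keep the number at this level. No measurement shown here explains why these two different groups give matching numbers.

Going by these compounds alone, this single step covers only one exchange on the sulfone side shared by compound 3 and compound 4, so it remains open whether the same tolerance would hold with the different sulfone groups of compound 1 or compound 2. It also leaves open how this position would respond to a group of another kind, such as a carboxylic acid or a longer chain ending in a hydroxyl group.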